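Adding a larger group where methyl raised the number

The source may report more compounds than this note shows. Statements on the series, on what has been measured and on what is new or still open speak of the compounds shown alone.

Measured so far in a functional assay on SK-OV-3 cells (Homo sapiens) for antiproliferative activity, read by MTT assay, with a stated time of 72 h; on this read-out lower numbers stand for stronger inhibition and higher numbers for weaker inhibition
Compound 1 (`O=C(CCc1cccc2c1B(O)OC2)Nc1ccccc1`) gives 200 nM
Compound 2 (`Cc1ccc(NC(=O)CCc2cccc3c2B(O)OC3)cc1`) gives 860 nM

Compound 2 stands highest of the two at 860 nM so far. Compound 3 (`CC(C)(C)OC(=O)Nc1ccc(NC(=O)CCc2cccc3c2B(O)OC3)cc1`) carries (tert-butoxycarbonyl)amino in place of methyl on an aromatic carbon para to a large group. Going by the values given here, one measured step bears on this: methyl in place of hydrogen gave a 4.3-fold higher number from compound 1 to compound 2 (0.63 log units; beyond the scatter) and was modest. On that single step, a further rise of similar size is expected in this assay with little certainty. The expected step is a 2.1-fold higher number from compound 2 to compound 3 (0.32 log units; beyond the scatter) by this estimate. For compound 3 the estimated value is 1800 nM within an expected range of 400 nM to 6000 nM in this assay.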

Compound 3, half-maximal inhibitory concentration: > 100000 nM
Compound 3 ended at the assay's limit; the forecaster's own chance of this, stated with the estimate: 5%; at least 55-fold (1.74 log units) between middle value and limit.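

Para to a large group, (tert-butoxycarbonyl)amino in place of methyl gives an at least 110-fold higher number from compound 2 to compound 3 (2.06 log units; beyond the scatter) in this assay, and in place of hydrogen it gives an at least 500-fold higher number from compound 1 to compound 3 (2.69 log units; beyond the scatter). Both steps are far larger than the modest one seen with methyl, so this position can separate compounds much more sharply than the first two values suggested. The value of compound 3 is a limit and not a number: the limit of > 100000 nM in this assay, at which 1 of the 3 values shown sits.

On these data alone, how far compound 3 truly lies past that limit remains open. So does where a smaller group at this position, such as a free amine or a methoxy group, would fall.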